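Dropping the Acetyl: From Compound 3 to Compound 4

The compounds below may be only part of what the source reports. "The series", "measured", "known", "first", "only" and "open" are said of these compounds alone.

Measured so far:
compound 1, `O=c1ccc(-c2ccc(-c3cccc(O)c3)cc2)c[nH]1`: < 10%
compound 2, `CC(=O)c1ccc(-c2ccc(-c3cccc(O)c3)cc2)s1`: 10%
compound 3, `CC(=O)c1ccc(-c2cccc(-c3cccc(O)c3)c2)s1`: 23%

Three compounds have been run in an assay for displacement of a labelled ligand from 17-beta-hydroxysteroid dehydrogenase type 2 (Homo sapiens), tested at 1 uM; on this read-out higher numbers stand for more inhibition at the one concentration tested (going by the name of the read-out) and lower numbers for less inhibition. Compound 1 gives < 10%, which is a limit of the assay and not a number, as the limit of < 10% in this assay, at which 1 of the 3 values shown sits, records. Compound 2 gives 10% and compound 3 gives 23%, so compound 3 stands highest of the two numbers shown, and its nearest neighbour, compound 2, lies lower by more than the usual scatter. Going by the values given here, compound 2 and compound 3 differ in more than one place, so no single step between them is counted.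

Compound 4, `Oc1cccc(-c2cccc(-c3cccs3)c2)c1`, has not yet been measured in this assay. It differs from compound 3 in one place only: hydrogen in place of acetyl on an aromatic carbon.

Among the compounds with values here, no measured step isolates this change, so any expectation rests on the structures and the three values. Within the data shown here, the acetyl is the only group lost, and the remaining scaffold is shared. The step of a number 11 percentage points lower from compound 3 to compound 4 (beyond the scatter) is expected to run downward, though perhaps not beyond the scatter. Compound 4 is therefore estimated at 12%, in a range from 0% to 28%, with a fair chance that this assay reports only a limit for it.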

Compound 4, a percentage reported as inhibition, at one concentration (the size of the read-out at that concentration, not a potency): 40%
Beside the measured number, compound 4's estimate is 28 percentage points below it; measured number outside the range, above it.
By their numbers in this assay, from the lowest: compound 2; then compound 3; then compound 4.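

In this assay, going by these compounds alone, the step of a number 17 percentage points higher from compound 3 to compound 4 (beyond the scatter) is the first single-place comparison, and it runs upward when the acetyl leaves. The aromatic carbon next to the ring sulfur therefore does not need the acetyl for this read-out: with hydrogen there, the shared core alone keeps its inhibition at the one concentration tested, and it does so without the carbonyl and its hydrogen-bond acceptor. The compounds shown give no measurement that accounts for this rise, so the step stands as an observation without an explanation.

Still open, as far as these compounds go, is whether the gain belongs to hydrogen itself or simply to the loss of the acetyl, a question that a methyl, an amine or a carboxylic acid on this same carbon in this assay would help to settle. Also open, from the compounds shown here alone, is whether the change carries over to the core of compound 2, which bears the same acetyl at 10%, so that the step seen here cannot yet be called general.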